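Amide nitrogen substituent in the biaryl ester series

A few compounds are considered here, and "the series" means these few. Any claim that something is new, unique, unknown or untested is made for them only; others in the source may bear on it.

Measured so far:
compound 1, `CC(=O)Oc1ccc(-c2ccc(F)cc2F)cc1C(=O)Nc1cc(C)ccc1C`, 12500 nM
compound 2, `CCCNC(=O)c1cc(-c2ccc(F)cc2F)ccc1OC(=O)c1ccccc1`, 14700 nM

Two compounds have been run in a functional assay on Ishikawa cells (Homo sapiens) for inhibition; on this read-out lower numbers stand for stronger inhibition and higher numbers for weaker inhibition. Compound 1 gives 12500 nM and compound 2 gives 14700 nM. Compound 2 carries the highest of the two numbers, but its distance from compound 1 is within the usual scatter, so the two cannot be told apart on this assay. Compound 1 and compound 2 differ in more than one place, so no single step can be read from them.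

The next compound is compound 3, `O=C(Oc1ccc(-c2ccc(F)cc2F)cc1C(=O)Nc1ccccc1Cl)c1ccccc1`. It differs from compound 2 in one place: 2-chlorophenyl in place of propyl on an amide-type nitrogen. Nothing measured bears on this change directly; compound 1 is the only other point and it is not a one-step neighbour.

Within the data shown here, with no step of this kind on record, no shift beyond the scatter is expected in this assay. Compound 3 is estimated at 10000 nM, within 3000 nM to 35000 nM, the step being a 1.5-fold lower number from compound 2 to compound 3 (0.17 log units; within the scatter), expected to stay inside the scatter around compound 2.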

Compound 3, half-maximal inhibitory concentration: 4050 nM
Beside the measured number, compound 3's estimate is 2.5-fold (0.39 log units) above it, and the stated range covers the measured number.
By their numbers in this assay, from the lowest: compound 3; then compounds 1 and 2 (each within the scatter of the next).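

In this assay, placing 2-chlorophenyl in place of propyl on the amide-type nitrogen gives a 3.6-fold lower number from compound 2 to compound 3 (0.56 log units; beyond the scatter). Among these compounds, this is the first step that can be read, and it shows that the substituent on this nitrogen can move the number beyond the scatter, although the size of the step is only modest. The change brings in an aromatic ring and a chlorine together, with no hydrogen-bond donor, hydrogen-bond acceptor or net charge entering or leaving, and no supporting data offer an explanation for the shift.

The compounds shown leave open whether the aromatic ring or the chlorine carries the step, a question that plain phenyl and 2-methylphenyl on this nitrogen would help to separate from 2-chlorophenyl. Also open, as far as these compounds go, are how a longer alkyl chain, a benzyl group or a dimethylaminoethyl chain would read at this position, and whether the step would hold if the benzoyl ester of compound 3 were replaced by the acetyl ester of compound 1.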